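The source may report more compounds than this note shows. Statements on the series, on what has been measured and on what is new or still open speak of the compounds shown alone.

Measured in a functional assay on HCT-116 cells (Homo sapiens) for antiproliferative activity, read by MTT assay, with a stated time of 72 h; on this read-out lower numbers stand for stronger inhibition and higher numbers for weaker inhibition:
- compound 1 `NC1=NC2(CCOCC2)N(OCCCOc2ccc(Cl)cc2)C(N)=N1` at 690 nM
- compound 2 `NC1=NC2(CCOCC2)N(OCCCOc2ccccc2Cl)C(N)=N1` at 70 nM
- compound 3 `NC1=NC2(CCOCC2)N(OCCCOc2ccccc2Br)C(N)=N1` at 30 nM

Compound 1 has the highest of these three numbers in this assay and is the reference here. Compound 4 `CC(C)(C)c1ccc(OCCCON2C(N)=NC(N)=NC23CCOCC3)cc1` has tert-butyl in place of chloro on an aromatic carbon, para to a large group (tert-butyl in place of chloro on an aromatic carbon). Among the measured compounds shown here, no measured step changes the group at that place. The nearest evidence is indirect: 2-chlorophenyl in place of 4-chlorophenyl gave a 9.9-fold lower number from compound 1 to compound 2 (0.99 log units; beyond the scatter), 2-bromophenyl in place of 4-chlorophenyl gave a 23-fold lower number from compound 1 to compound 3 (1.36 log units; beyond the scatter), and bromo in place of chloro gave a 2.3-fold lower number from compound 2 to compound 3 (0.37 log units; beyond the scatter). These steps show sensitivity to the aryl substitution but set no direction for tert-butyl, so no clear shift is expected. The expected outcome is a 1.2-fold higher number from compound 1 to compound 4 (0.06 log units; within the scatter), which stays within the scatter. For compound 4 the estimate is 800 nM, with an expected range of 200 nM to 3000 nM.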

Compound 4, half-maximal inhibitory concentration: 1610 nM
Beside the measured number, compound 4's estimate is 2.0-fold (0.30 log units) below it; low and high end bracket the measured number.
By their numbers in this assay, from the lowest: compound 3; then compound 2; then compound 1; then compound 4.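

In this assay, tert-butyl in place of chloro on an aromatic carbon, para to a large group, gives a 2.3-fold higher number from compound 1 to compound 4 (0.37 log units; beyond the scatter). Among the compounds shown here, this is the first step that changes the group at this place while the place itself stays the same, and it shows that the number responds to that group. Going from one heavy atom to four raises the number, though only modestly. Nothing measured here gives a reason for this step.

Going by these compounds, whether an amine or a carboxylic acid at this place would move the number, and in which direction, remains open.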